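This account rests on a few compounds, and the source may have more. Where it says the series, first, only, none or still open, it means among the compounds named here.

Measured compounds in a functional assay on the whole organism with Rattus norvegicus as the target, at a dose of 20 mg/kg by the intraperitoneal route; on this read-out lower numbers stand for less inhibition and higher numbers for more inhibition at the one dose given (going by the name of the read-out):

Compound 1, `Nc1nc(N)nc(-c2cccc(Br)c2)n1`, gives 96%.
Compound 2, `Nc1nc(N)nc(-c2cccc(Cl)c2)n1`, gives 100%.
Compound 3, `Nc1nc(N)nc(-c2ccc(Cl)cc2Br)n1`, gives 96%.

All three measured compounds share the same core and sit close together on this read-out. From compound 1 to compound 2 the change is chloro in place of bromo on an aromatic carbon, and the step it made was a number 4 percentage points higher from compound 1 to compound 2 (within the scatter). Compound 3 carries a different substitution pattern from compound 1; the difference between the two cores is not broken down here. Its value stands level with that of compound 1 at the digits reported, and lies within the scatter of that of compound 2.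

Compound 4, `Nc1nc(N)nc(-c2ccc(Cl)cc2Cl)n1`, has not yet been measured. It arises from compound 3 by chloro in place of bromo on an aromatic carbon. Among the compounds with values here, this is the same kind of change as the one from compound 1 to compound 2, but not the same: in compound 1 the exchanged halogen sits meta to a group of 8 heavy atoms, whereas in compound 3 it sits ortho to a group of 8 heavy atoms and meta to a chloro group.

Because a number 4 percentage points higher from compound 1 to compound 2 (within the scatter) stayed within the scatter, the same kind of change from compound 3 to compound 4 is expected to give a step of a number 1 percentage points higher from compound 3 to compound 4 (within the scatter). Compound 4 is therefore estimated at 97%, with a range from 88% to 100%, resting on compound 3 giving 96%.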

Compound 4, a percentage reported as inhibition, in the whole organism at one dose (the size of the read-out at that dose, not a potency): 100%
The estimate for compound 4 lay 3 percentage points below the measured number, within the range that was stated.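

In this assay, chloro in place of bromo on an aromatic carbon gave a step of a number 4 percentage points higher from compound 3 to compound 4 (within the scatter), and this step does not differ from the earlier one on the other core: the same change on two cores in this assay, a number 4 percentage points higher (within the scatter) from compound 1 to compound 2 and a number 4 percentage points higher (within the scatter) from compound 3 to compound 4, 0 percentage points apart, within the scatter of two such steps. Within this pair of examples, the exchange therefore carried over from the core of compound 1 to the core of compound 3 without a visible difference, even though in compound 3 the exchanged halogen sits ortho to a group of 8 heavy atoms and meta to a chloro group. This does not show that the exchange itself moves the read-out, as neither step lies beyond the scatter, and two pairs tested at a single dose cannot establish a rule for the whole series.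

The compounds shown leave open how the read-out responds when the halogens on the aromatic ring give way to other groups, such as a methoxy group, a nitrile or a trifluoromethyl group. They also leave open what happens when the amino groups on the shared core are replaced, for instance by a longer alkyl amine or a carboxylic acid.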